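Swapping the aryl group on the hydrazone of compound 1

A few compounds are considered here, and "the series" means these few. Any claim that something is new, unique, unknown or untested is made for them only; others in the source may bear on it.

Measured so far:
compound 1 `COc1ccc(/C=N/NC(=O)Nc2ccc(Oc3ccnc(-c4nncn4CCN(C)C)c3)c(F)c2)c(OC)c1` gives 1780 nM
compound 2 `Cn1ncnc1-c1cc(Oc2ccc(NC(=O)N/N=C/c3ccccc3)cc2F)ccn1` gives 30200 nM
compound 3 `COc1cc(/C=N/NC(=O)Nc2ccc(Oc3ccnc(-c4nncn4CCN(C)C)c3)c(F)c2)cc(OC)c1OC` gives 3620 nM

In a functional assay on HT-29 cells (Homo sapiens) for cytotoxicity, read by MTT assay, with a stated time of 72 h (a lower number here means a stronger inhibitor, a higher number a weaker inhibitor), compound 1 stands lowest of the three numbers. Going by the values given here, compound 3 is its nearest neighbour, and the step of a 2.0-fold higher number from compound 1 to compound 3 (0.31 log units; beyond the scatter) is the only one measured that changes the aryl group on the hydrazone. Among the compounds with values here, compound 2, which lacks the dimethylaminoethyl chain and carries a plain phenyl, gives a far higher number, but no single-change step links it to compound 1.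

Compound 4 `CN(C)CCn1cnnc1-c1cc(Oc2ccc(NC(=O)N/N=C/c3cccc(Cl)c3Cl)cc2F)ccn1` differs from compound 1 in one place: 2,3-dichlorophenyl in place of 2,4-dimethoxyphenyl on a carbon with a double bond to nitrogen. Within the data shown here, the one step that bears on this change was modest, so the step of a 1.8-fold higher number from compound 1 to compound 4 (0.25 log units; within the scatter) is expected to be similarly modest, towards a higher number. Compound 4 is therefore estimated at 3200 nM, within 1100 nM to 9500 nM.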

Compound 4, half-maximal inhibitory concentration: 130 nM
For compound 4 the middle estimate is 25-fold (1.39 log units) above the measured one; measured number below the stated range.
By their numbers in this assay, from the lowest: compound 4; then compound 1; then compound 3; then compound 2.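

With 2,3-dichlorophenyl on the carbon with a double bond to nitrogen, this assay shows a 14-fold lower number from compound 1 to compound 4 (1.14 log units; beyond the scatter) and a 28-fold lower number from compound 3 to compound 4 (1.44 log units; beyond the scatter), so this position can shift the number far more than the exchange between the two methoxy-bearing aryl groups suggested. Both steps replace oxygen-bearing substituents with chlorine, and both go the same way. Nothing available explains this gain.

The compounds shown leave open whether both chlorines are needed, or whether a phenyl carrying a single chlorine or two bromines would give a similar number.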